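Lengthening the Alkyl Chain on a Cytotoxic Core

A few compounds are considered here, and "the series" means these few. Any claim that something is new, unique, unknown or untested is made for them only; others in the source may bear on it.

Compound 3 `CCCc1nc2c(-c3ccc(Cl)cc3)n[nH]c2c(=O)n1NC(=O)c1ccccc1` gives 89.4% in a functional assay on DU-145 cells (Homo sapiens) for cytotoxicity, read by sulforhodamine B assay, with a stated time of 2 days, tested at 100 uM (on this read-out lower numbers stand for less inhibition and higher numbers for more inhibition at the one concentration tested (going by the name of the read-out)), and it stands within the usual scatter of the two compounds measured alongside it. Compound 1 `O=C(Nn1c(-c2cccc([N+](=O)[O-])c2)nc2c(-c3ccc(Cl)cc3)n[nH]c2c1=O)c1ccccc1` gives 94.3% in this assay, and compound 2 `O=C(Nn1c(-c2ccccc2)nc2c(-c3ccc(Cl)cc3)n[nH]c2c1=O)c1ccccc1` gives 90.2%. The step of a number 4.1 percentage points lower from compound 1 to compound 2 (within the scatter) and the step of a number 4.9 percentage points lower from compound 1 to compound 3 (within the scatter) both show that swapping a 3-nitrophenyl for a phenyl or for a propyl at that aromatic carbon leaves the read-out essentially unchanged, and the step of a number 0.8 percentage points lower from compound 2 to compound 3 (within the scatter) confirms that a propyl in place of a phenyl makes no difference beyond the scatter.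

Compound 4 `CCCCc1nc2c(-c3ccc(Cl)cc3)n[nH]c2c(=O)n1NC(=O)c1ccccc1` carries the change (methyl in place of hydrogen on a saturated chain carbon, three bonds along the chain from an aromatic carbon). Among the compounds with values here, no measured step alters the length of this saturated chain, so the closest guide is the step of a number 0.8 percentage points lower from compound 2 to compound 3 (within the scatter), where a quite different group at the same aromatic carbon left the read-out flat. All three measured compounds cluster near the top of the scale, which leaves little room for an increase and gives no hint of a decrease.

Compound 3 to compound 4 is therefore expected to be a step of a number 0.4 percentage points lower from compound 3 to compound 4 (within the scatter), within the scatter. For compound 4 the estimate in this assay is 89%, with a range from 80% to 96%.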

Compound 4, a percentage reported as inhibition, at one concentration (the size of the read-out at that concentration, not a potency): 93.1%
Estimate against measurement, compound 4: 4.1 percentage points below; measured number inside the range.
By their numbers in this assay, from the lowest: compounds 3, 2, 4 and 1 (each within the scatter of the next).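

Methyl in place of hydrogen on a saturated chain carbon, three bonds along the chain from an aromatic carbon, gives in this assay a step of a number 3.7 percentage points higher from compound 3 to compound 4 (within the scatter) and so shows that the read-out does not separate the propyl and butyl chains. Butyl also reads the same as the two aromatic groups at this aromatic carbon, with butyl in place of phenyl giving a number 2.9 percentage points higher from compound 2 to compound 4 (within the scatter) and butyl in place of 3-nitrophenyl giving a number 1.2 percentage points lower from compound 1 to compound 4 (within the scatter) and thereby extending the flat picture from the earlier compounds to a fourth group. Nothing among the available findings bears on why these compounds read alike.

As far as these compounds go, since each number is the size of the read-out at a single concentration and not a potency, it remains open whether these four compounds would separate at lower concentrations. From the compounds shown here alone, it also remains open whether a longer chain such as hexyl, a branched chain such as isobutyl, or a chain ending in an amine or a carboxylic acid would leave the read-out as flat as butyl does.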